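Swapping tert-butyl for 2-methoxyethyl on the amine

The source may hold more compounds than are shown below. What is called first, only, known or untested is meant among the compounds shown, and "the series" means these compounds.

Of the compounds shown here, three have been tested in an ADME assay on cells (Homo sapiens) for cytotoxicity, read by polymerase chain reaction, with a stated time of 3 days; a higher number here means that more compound is tolerated, a lower number that less compound is tolerated. Compound 1 `Nc1nc(Cl)c(-c2ccco2)c(N[C@@H]2C[C@H](CO)[C@@H](O)[C@H]2O)n1` reaches only the limit of the assay, > 25000 nM, which is a boundary and not a number (the limit of > 25000 nM in this assay, at which 1 of the 3 values shown sits). Compound 2 `CNc1ccc2sc(-c3c(Cl)nc(N)nc3N[C@@H]3C[C@H](CO)[C@@H](O)[C@H]3O)nc2c1` gives 20000 nM. Compound 3 `Cc1nc(NC(C)(C)C)nc(N[C@@H]2C[C@H](CO)[C@@H](O)[C@H]2O)c1-c1nc2ccccc2s1` gives 12000 nM, the lower of the two measured numbers, though its gap to compound 2 lies within the scatter of this assay. Compound 4 `COCCNc1nc(C)c(-c2nc3ccccc3s2)c(N[C@@H]2C[C@H](CO)[C@@H](O)[C@H]2O)n1` has not yet been measured; it differs from compound 3 by 2-methoxyethyl in place of tert-butyl on a nitrogen on an aromatic ring. Going by the values given here, no step of this kind has been measured here, so little movement beyond the scatter is expected, with a 1.3-fold higher number from compound 3 to compound 4 (0.10 log units; within the scatter) as the estimated step. Compound 4 is therefore expected to give about 15000 nM, within a range from 6000 nM to 40000 nM.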

Compound 4, half-maximal cytotoxic concentration: 21000 nM
For compound 4 the middle estimate is 1.4-fold (0.15 log units) below the measured one; measured number inside the range.
By their numbers in this assay, from the lowest: compounds 3, 2 and 4 (each within the scatter of the next). At a limit, above all of these: compound 1.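

Going by these compounds alone, for this assay, this is the only reading of a change on a nitrogen on an aromatic ring: 2-methoxyethyl in place of tert-butyl gives a 1.8-fold higher number from compound 3 to compound 4 (0.24 log units; within the scatter). At this place, then, the exchange, with the hydrogen-bond acceptor that 2-methoxyethyl brings, shows no movement beyond the scatter. Nothing measured here bears on the reason for this step. The compounds shown leave open whether a longer chain, or a chain ending in an amine or a carboxylic acid, would behave the same way on this nitrogen.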